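This account rests on a few compounds, and the source may have more. Where it says the series, first, only, none or still open, it means among the compounds named here.

Compound 1 `CN1CCCN(CCn2ccc3ccc(Br)cc32)CC1` carries a bromo group on its aromatic ring and a methyl group on one of the two amine nitrogens of the saturated ring. In an assay on HEK293 cells for binding affinity to 5-hydroxytryptamine receptor 7 (Homo sapiens), read by radioligand binding, tested at 1 uM (on this read-out higher numbers stand for more inhibition at the one concentration tested (going by the name of the read-out) and lower numbers for less inhibition), compound 1 gives 93%, the highest of the three measured numbers. Compound 2 `CN1CCCN(CCn2ccc3ccc(N)cc32)CC1` gives 0% and compound 3 `CN1CCCN(CCn2ccc3ccc(-c4cccnc4)cc32)CC1` gives 35%, so the step of a number 93 percentage points lower from compound 1 to compound 2 (beyond the scatter) and the step of a number 58 percentage points lower from compound 1 to compound 3 (beyond the scatter) both show that replacing the bromo group on the aromatic carbon costs much of the inhibition, and the step of a number 35 percentage points higher from compound 2 to compound 3 (beyond the scatter) recovers part of it.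

Compound 4 `Brc1ccc2ccn(CCN3CCCN(CC4CC4)CC3)c2c1` keeps the bromo group of compound 1 untouched and changes instead the other end of the molecule: cyclopropyl in place of hydrogen on a saturated chain carbon bound to an amine nitrogen in a ring. None of the three measured steps touches this place; all of them vary the aromatic carbon, so nothing measured here shows whether a change at the saturated chain carbon bound to the amine nitrogen leaves the number higher, lower or level. The bromo group, which every measured step shows to matter, stays in place, so the number for compound 4 is expected to stay near that of compound 1, with a wide range to reflect the absence of any directly comparable step. Compound 4 is expected to give 82%, between 50% and 98%, an expected step of a number 11 percentage points lower from compound 1 to compound 4 (beyond the scatter).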

Compound 4, a percentage reported as inhibition, at one concentration (the size of the read-out at that concentration, not a potency): 95%
The estimate for compound 4 lay 13 percentage points below the measured number; measured number inside the range.
By their numbers in this assay, from the lowest: compound 2; then compound 3; then compounds 1 and 4 (each within the scatter of the next).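

In this assay, the change from methyl to cyclopropylmethyl gives a number 2 percentage points higher from compound 1 to compound 4 (within the scatter), so adding cyclopropyl at this place leaves the number level. The earlier steps shown here all varied the aromatic carbon, and each replacement of the bromo group there moved the number by a large amount, whereas this step shows that a saturated chain carbon bound to an amine nitrogen in a ring can carry 3 more heavy atoms with no change beyond the scatter. No measurement offered here explains why the number holds at this place.

From the compounds shown here alone, both numbers lie high on a read-out taken at a single concentration, so a difference in potency between these two compounds could remain hidden, and it is still open whether a larger group, such as benzyl, or a hydroxyethyl chain would be accepted at this place as well. Going by these compounds, it is also open whether cyclopropylmethyl would leave the number level when the amino or pyridin-3-yl group stands in place of the bromo group.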